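Swapping Methoxymethyl for Phenyl on the Shared Core

A few compounds are considered here, and "the series" means these few. Any claim that something is new, unique, unknown or untested is made for them only; others in the source may bear on it.

compound 1 `COCc1cc2cc(/C(=N\O)Nc3cccc(F)c3)ccc2o1`: 7100 nM
compound 2 `COCc1cc2cc(/C(=N\O)Nc3cccc(Cl)c3)ccc2o1`: 1000 nM
compound 3 `COCc1cc2cc(/C(=N\O)Nc3cccc(Br)c3)ccc2o1`: 930 nM

In an assay on isolated protein for inhibition of Indoleamine 2,3-dioxygenase 1 (Homo sapiens), read by spectrophotometry (on this read-out lower numbers stand for stronger inhibition and higher numbers for weaker inhibition), compound 3 gives 930 nM. Compound 2 and compound 3 sit together at the low end, since a 1.1-fold lower number from compound 2 to compound 3 (0.03 log units; within the scatter) lies within the scatter, whereas a 7.6-fold lower number from compound 1 to compound 3 (0.88 log units; beyond the scatter) and a 7.1-fold lower number from compound 1 to compound 2 (0.85 log units; beyond the scatter) are both beyond it. Compound 4 `O/N=C(/Nc1cccc(Br)c1)c1ccc2oc(-c3ccccc3)cc2c1` is not yet measured; it differs from compound 3 by phenyl in place of methoxymethyl on an aromatic carbon. None of the three measured steps bears on this change: each of them swaps one halogen for another and leaves the methoxymethyl untouched. So there is no measured step from which to read the direction or size of this replacement, and the expectation rests only on compound 3 itself, with a wide range. Compound 4 is expected to give about 900 nM in this assay, between 200 nM and 4000 nM. This estimate means a step of a 1.0-fold lower number from compound 3 to compound 4 (0.01 log units; within the scatter) that is expected to stay within the scatter.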

Compound 4, half-maximal inhibitory concentration: 900 nM
For compound 4 middle estimate and measured number coincide at the digits printed; low and high end bracket the measured number.
By their numbers in this assay, from the lowest: compounds 4, 3 and 2 (each within the scatter of the next); then compound 1.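

In this assay, phenyl in place of methoxymethyl on the aromatic carbon next to the ring oxygen gives a 1.0-fold lower number from compound 3 to compound 4 (0.01 log units; within the scatter), so the two compounds cannot be told apart. The earlier compounds shown here changed only the halogen and left this position untouched; this step shows that, with bromo in place, a group of 3 heavy atoms and 1 hydrogen-bond acceptor can give way to an aromatic ring of 6 heavy atoms and no acceptor with no change beyond the scatter. No available evidence explains why these two groups read alike.

Going by these compounds, whether an amine, a carboxylic acid or a longer chain at this position would read the same remains open. On these data alone, it is also open whether the gap between fluoro and chloro seen with methoxymethyl would persist with phenyl.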